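The compounds below may be only part of what the source reports. "The series", "measured", "known", "first", "only" and "open" are said of these compounds alone.

Measured in a functional assay on PC-3 cells (Homo sapiens) for cytotoxicity, read by MTT assay, with a stated time of 24 h; a higher number here means a weaker inhibitor, a lower number a stronger inhibitor:
- Compound 1 `C=C1C(=O)[C@@]23C[C@@H]1CC[C@@H]2[C@@]1(C)CCCC(C)(C)[C@@H]1COC3=O` gives 11500 nM as a number
- Compound 2 `CCOC1C=C(CC[C@]2(C)[C@@H](C)CC[C@@]3(C)C(C(=O)O)=CCC[C@@H]23)C(=O)O1` gives > 40000 nM as a limit
- Compound 3 `C=C1CC[C@H](C)[C@@](C)(CCC2=CC(O)OC2=O)C/C=C\C=C/1C(=O)O` gives > 40000 nM as a limit

Compound 3 has no number, only a limit (> 40000 nM). It stands with the majority of the series (the limit of > 40000 nM in this assay, at which 2 of the 3 values shown sit). Compound 4 `C=C1CC[C@H](C)[C@@](C)(CCC2=CC(OC)OC2=O)C/C=C\C=C/1C(=O)O` differs from compound 3 by hydroxy to methoxy (methyl in place of hydrogen on an oxygen on a saturated carbon). Within the data shown here, no measured pair shows this change, so in this assay no step beyond the scatter is expected, in either direction. The expected step (a number no higher from compound 3 to compound 4 (the limit leaves the size open)) is small. This expectation rests on the limit of compound 3 (> 40000 nM). Compound 4 is estimated at 40000 nM with an expected range from 20000 nM to 80000 nM in this read-out.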

Compound 4, half-maximal inhibitory concentration: > 40000 nM
Compound 4 was reported as a limit; the forecaster's own chance of this, stated with the estimate: 75%; the middle value sits exactly at the limit.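

Among these compounds, compound 3 and compound 4 both stand only as limits in this assay; no step between them can be read. Going by these compounds, whether hydroxy to methoxy shifts the read-out at all stays open, as neither compound carries a number.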